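The source may report more compounds than this note shows. Statements on the series, on what has been measured and on what is new or still open speak of the compounds shown alone.

Three compounds built on a shared core have been assessed in an ADME assay on Vero cells (Chlorocebus sabaeus) for cytotoxicity, read by fluorescence and resazurin assay, with a stated time of 72 h; on this read-out higher numbers stand for lower toxicity in this test and lower numbers for higher toxicity in this test. Compound 1 `CC1=CSC2=NC(/C=C/c3ccc(F)cc3)=C(C(=O)/C=C/c3ccc(F)cc3)C(c3ccccc3)N12` gives 306 ug/mL in this assay. Compound 2 `COc1ccc(/C=C/C(=O)C2=C(/C=C/c3ccc(OC)cc3)N=C3SC=C(C)N3C2c2ccccc2)cc1` gives 358 ug/mL in this assay, and compound 3 `COc1cc(/C=C\C2=C(C(=O)/C=C/c3cc(OC)c(OC)c(OC)c3)C(c3cc(OC)c(OC)c(OC)c3)N3C(C)=CSC3=N2)cc(OC)c1OC` gives 167 ug/mL in this assay. Compound 2 stands at the highest of the three numbers; the reading for compound 1 lies within the scatter of it, while the reading for compound 3 lies beyond that scatter and is the smaller of the pair.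

Compound 4 `COc1ccc(/C=C/C(=O)C2=C(/C=C/c3ccc(OC)cc3)N=C3SC=C(C)N3C2c2cc(OC)c(OC)c(OC)c2)cc1` has not yet been measured in this assay. It differs from compound 2 in one place: 3,4,5-trimethoxyphenyl in place of phenyl on a saturated ring carbon. Within the data shown here, no step between two measured compounds that differ in a single place is available, so the expectation rests on compound 2 and compound 3 alone, and compound 3, which carries the 3,4,5-trimethoxyphenyl group, shows the smaller number of that pair in this assay. A step of modest size toward a lower number is therefore expected from compound 2 to compound 4, near the edge of the scatter a 1.3-fold lower number from compound 2 to compound 4 (0.12 log units; within the scatter). Compound 4 is estimated at 270 ug/mL in this assay, with a range from 160 ug/mL to 420 ug/mL.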

Compound 4, half-maximal cytotoxic concentration: 348 ug/mL
The estimate for compound 4 lay 1.3-fold (0.11 log units) below the measured number, and the stated range covers the measured number.
By their numbers in this assay, from the lowest: compounds 3, 1, 4 and 2 (each within the scatter of the next, the first and the last beyond it).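

In this assay, the change at this position can now be read by itself: 3,4,5-trimethoxyphenyl in place of phenyl on the saturated ring carbon gives a 1.0-fold lower number from compound 2 to compound 4 (0.01 log units; within the scatter) with everything else in the structure held the same. The read-out therefore does not separate these two groups at this carbon, at least with the two 2-(4-methoxyphenyl)ethenyl-derived side groups of compound 2 in place. Nothing in the data given accounts for this result. As far as these compounds go, whether an amine or a carboxylic acid on the aromatic ring at this carbon would also stay within the scatter of compound 2 remains open, as does the same change on the fluorinated side groups of compound 1. Also open, from the compounds shown here alone, is which of its several differences from compound 2 goes with the reading of compound 3.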